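A few compounds are considered here, and "the series" means these few. Any claim that something is new, unique, unknown or untested is made for them only; others in the source may bear on it.

Notes on the series. Compound 1 `c1ccc(-c2ccc(-c3ccc(-c4nc5ccccc5[nH]4)cc3)cc2)cc1` gives 100000 nM in a functional assay on COLO 205 cells (Homo sapiens) for inhibition, read by sulforhodamine B assay; on this read-out higher numbers stand for weaker inhibition of growth and lower numbers for stronger inhibition of growth. Compound 2 `COc1ccc(-c2ccc(-c3ccc(-c4nc5ccccc5[nH]4)cc3)cc2)cc1` gives 45200 nM in this assay. The change between them is methoxy in place of hydrogen on an aromatic carbon and the step of a 2.2-fold lower number from compound 1 to compound 2 (0.34 log units; beyond the scatter) is a modest one. Compound 3 `COc1ccc(-c2ccc(-c3ccc(-c4nc5c(O)cccc5[nH]4)cc3)cc2)cc1OC` gives 1320 nM in this assay, the lowest number of the three measured compounds; the difference between its core and that of compound 1 is not broken down here. Compound 4 `COc1cc(-c2ccc(-c3ccc(-c4nc5c(O)cccc5[nH]4)cc3)cc2)cc(OC)c1OC` is not yet measured; it differs from compound 3 by methoxy in place of hydrogen on an aromatic carbon, the same kind of change as between compound 1 and compound 2, but the place differs: ortho to a methoxy group and meta to a large group and to a methoxy group, rather than para to a large group. Because a 2.2-fold lower number from compound 1 to compound 2 (0.34 log units; beyond the scatter) was modest, a modest step of similar size is expected from compound 3 to compound 4, a 1.7-fold lower number from compound 3 to compound 4 (0.22 log units; within the scatter). Compound 4 is estimated at 800 nM in this assay, likely between 300 nM and 2500 nM.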

Compound 4, concentration for 50% growth inhibition: 190 nM
Beside the measured number, compound 4's estimate is 4.2-fold (0.62 log units) above it; measured number below the stated range.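

In this assay, methoxy in place of hydrogen on an aromatic carbon again lowers the number, with a 6.9-fold lower number from compound 3 to compound 4 (0.84 log units; beyond the scatter), so the direction of the change holds on both cores shown. The size does not carry over from one core to the other: the same change on two cores in this assay, a 2.2-fold lower number (0.34 log units; beyond the scatter) from compound 1 to compound 2 and a 6.9-fold lower number (0.84 log units; beyond the scatter) from compound 3 to compound 4, 3.1-fold (0.50 log units) apart, beyond the scatter of two such steps The two steps also differ in where the methoxy group sits on the ring, so two pairs cannot separate the part of the core from the part of the place, and they give no rule for other cores.

Open, going by these compounds, is how an amine, a carboxylic acid or a longer chain such as ethoxy would compare with methoxy at the same place. Also open, on these data alone, is what the same place would give on the core of compound 1.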